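The source may report more compounds than this note shows. Statements on the series, on what has been measured and on what is new or still open speak of the compounds shown alone.

Working notes on the oxazole ketone series.

Compound 1 `Cc1cccc(-c2cnc(C(=O)CCCCCCc3ccccc3)o2)n1` is the reference point; in an assay (Rattus norvegicus) for inhibition of Fatty-acid amide hydrolase 1 (Homo sapiens) (on this read-out higher numbers stand for weaker inhibition and lower numbers for stronger inhibition), compound 1 gives 3.3 nM. Compound 2 `O=C(CCCCCCc1ccccc1)c1ncc(-c2ncccc2C(=O)O)o1` carries 3-carboxypyridin-2-yl in place of 6-methylpyridin-2-yl on an aromatic carbon. In this assay compound 2 reaches only a limit, > 50 nM, so no number is known for it. The change is an at least 15-fold higher number from compound 1 to compound 2 (1.18 log units; beyond the scatter); because of the limit of > 50 nM in this assay, at which 1 of the 2 values shown sits, the true size of that step is open upward, and compound 2 stands at the weak end of the numbers shown.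

Compound 3 `CC(=O)c1cnc(C(=O)CCCCCCc2ccccc2)o1` is the next step from compound 2. The change is acetyl in place of 3-carboxypyridin-2-yl on an aromatic carbon. Among the measured compounds shown here, the only measured step that bears on it is the one from compound 1 to compound 2, which removed the methyl-bearing pyridyl in favour of the carboxy-bearing one and cost at least the size just given. Compound 3 drops the carboxypyridyl altogether for a much smaller group, so the number is expected to move back down by an at least 3.3-fold lower number from compound 2 to compound 3 (0.52 log units; beyond the scatter). The estimate for compound 3 is 15 nM, within 3 nM to 80 nM, with a fair chance that the assay again reports only a limit.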

Compound 3, inhibition constant: 2 nM
For compound 3 the middle estimate is 7.5-fold (0.88 log units) above the measured one; measured number outside the range, below it.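

In this assay, the position next to the ring oxygen tolerates a group with no ring: acetyl and 6-methylpyridin-2-yl sit within the scatter of each other, the step being a 1.7-fold lower number from compound 1 to compound 3 (0.22 log units; within the scatter). The earlier pair left unclear whether anything smaller than a substituted pyridine could serve here, and this result shows that the weak reading belongs to 3-carboxypyridin-2-yl specifically and not to leaving 6-methylpyridin-2-yl behind, with the step back being an at least 25-fold lower number from compound 2 to compound 3 (1.39 log units; beyond the scatter). The true size of that step is open upward because compound 2 is known only through a limit and not a number: the limit of > 50 nM in this assay, at which 1 of the 3 values shown sits.

As far as these compounds go, whether the weak reading of compound 2 goes with the carboxylic acid itself or with the pyridine ring that carries it remains open, and an unsubstituted pyridin-2-yl or a methyl ester at this position would separate the two. From the compounds shown here alone, how far the group can shrink or grow also stays open, from a bare hydrogen to a longer acyl chain such as propanoyl.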